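Cyclohexyl for methyl on the ring nitrogen: cytotoxicity outlook

The compounds below may be only part of what the source reports. "The series", "measured", "known", "first", "only" and "open" are said of these compounds alone.

Compound 3 `CCC(=O)Nc1ccc(-c2nc3cc(C(F)(F)F)ccc3n2C)cc1` gives 8000 nM in an ADME assay on MT4 cells (Homo sapiens) for cytotoxicity, read by MTT assay, with a stated time of 96 h (a higher number here means that more compound is tolerated, a lower number that less compound is tolerated), the lowest of the two numbers at hand. Compound 1 `CC(=O)Nc1ccc(-c2nc3cc(C(F)(F)F)ccc3n2C2CCCCC2)cc1` gives 24000 nM, a higher number beyond the scatter. Compound 2 `Cn1c(-c2ccc([N+](=O)[O-])cc2)nc2cc(C(F)(F)F)ccc21` reaches only a limit of this assay, >= 100000 nM. Within the data shown here, the one measured step, an at least 12-fold lower number from compound 2 to compound 3 (1.09 log units; beyond the scatter), concerns the amide end and does not touch the change now at hand. Compound 4 `CCC(=O)Nc1ccc(-c2nc3cc(C(F)(F)F)ccc3n2C2CCCCC2)cc1` differs from compound 3 by cyclohexyl in place of methyl on an aromatic nitrogen. Among the measured compounds shown here, no measured step speaks directly to this exchange; compound 1, which also carries the cyclohexyl group, gives a higher number than compound 3, and the account leans on that. Compound 4 is therefore expected to give a somewhat higher number, 16000 nM with a range from 5000 nM to 50000 nM, an expected step of a 2.0-fold higher number from compound 3 to compound 4 (0.30 log units; within the scatter).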

Compound 4, half-maximal cytotoxic concentration: 17000 nM
Compound 4: middle estimate off by 1.1-fold (0.03 log units), on the low side, within the range that was stated.
By their numbers in this assay, from the lowest: compound 3; then compounds 4 and 1 (each within the scatter of the next). At a limit, above all of these: compound 2.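

In this assay cyclohexyl in place of methyl on the aromatic nitrogen now has its own measured step, a modest one, giving a 2.1-fold higher number from compound 3 to compound 4 (0.33 log units; beyond the scatter) with the propanoylamino group held fixed. With cyclohexyl on that nitrogen, methyl in place of hydrogen on the chain carbon bound to the carbonyl carbon gives a 1.4-fold lower number from compound 1 to compound 4 (0.15 log units; within the scatter) and so sets no order between the two compounds. Nothing measured here bears on why the cyclohexyl step has this size. From the compounds shown here alone, whether it holds for an ethyl or a phenyl group on that nitrogen, or with a free amine in place of the amide, stays open.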